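Phenyl for pyridin-2-yl at the thioether-bearing chain carbon

A few compounds are considered here, and "the series" means these few. Any claim that something is new, unique, unknown or untested is made for them only; others in the source may bear on it.

Compound 1 `CC(Sc1nc2c(cnn2C)c(=O)n1-c1ccccc1)c1ccccn1` and compound 2 `CC(Sc1nc2nn(C3COC3)cc2c(=O)n1-c1ccccc1)c1ccccc1` have both been run in an ADME assay on the whole organism (Mus musculus, strain CD-1) for metabolic stability, read by LC-MS, with a stated time of 4 h, at a dose of 10 mg/kg by the intraperitoneal route; on this read-out lower numbers stand for a shorter-lived compound and higher numbers for a longer-lived compound. Compound 1 gives 1.2 h, and compound 2 gives 2.1 h; the two numbers lie within the scatter of each other, so compound 1 cannot be set apart from compound 2 on this read-out. Compound 3 `CC(Sc1nc2c(cnn2C)c(=O)n1-c1ccccc1)c1ccccc1` is not yet measured. Relative to compound 1 it carries phenyl in place of pyridin-2-yl on a saturated chain carbon bound to a saturated chain carbon and a sulfur. Among the compounds with values here, no measured pair isolates this change, so the step of a 1.3-fold higher number from compound 1 to compound 3 (0.10 log units; within the scatter) is expected to stay within the scatter, if anything toward a longer half-life. Compound 3 is estimated at 1.5 h, with a range of 0.8 h to 3 h.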

Compound 3, half-life: 1.8 h
Compound 3: the middle estimate sits 1.2-fold (0.08 log units) below what was measured; the range from low to high includes it.
By their numbers in this assay, from the lowest: compounds 1, 3 and 2 (each within the scatter of the next).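

In this assay, within the data shown here, phenyl in place of pyridin-2-yl on a saturated chain carbon bound to a saturated chain carbon and a sulfur gives a 1.5-fold higher number from compound 1 to compound 3 (0.18 log units; within the scatter) on the core of compound 1, the only reading so far that isolates this change. At this position the exchange of these two rings therefore cannot be told apart on this read-out. No measurement on hand bears on the reason for this result.

As far as these compounds go, whether a dimethylamino group or a carboxylic acid on this chain carbon would give a step beyond the scatter stays open. So does whether the same ring exchange reads alike on the core of compound 2.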